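Shortening the Ester Chain on a Compound at the Limit

The compounds below may be only part of what the source reports. "The series", "measured", "known", "first", "only" and "open" are said of these compounds alone.

Compound 1 `C=CCN(CCCC(=O)OCC)C(=O)/C(C)=C/c1ccc(C(=O)Oc2ccc(C(=N)N)cc2)cc1` carries on its amide-type nitrogen an allyl group and a 3-(ethoxycarbonyl)propyl chain. In an in vitro ADME assay on a cell-free system (plasma) for pharmacokinetics (on this read-out lower numbers stand for a shorter-lived compound and higher numbers for a longer-lived compound), compound 1 gives < 0.0167 h, which is a limit of the assay and not a number. Compound 2 `CCOC(=O)CN(Cc1ccccc1)C(=O)/C(C)=C/c1ccc(C(=O)Oc2ccc(C(=N)N)cc2)cc1` bears a benzyl group and an (ethoxycarbonyl)methyl chain on the same nitrogen; in this assay compound 2 gives < 0.0167 h, again a limit. Among the compounds with values here, compound 3 `CCOC(=O)CCCN(C(=O)/C(C)=C/c1ccc(C(=O)Oc2ccc(C(=N)N)cc2)cc1)C(C(=O)O)C(=O)OCC` is the only one with a number: in this assay compound 3 gives 0.233 h. Within the data shown here, the single measured step, an at least 13-fold higher number from compound 1 to compound 3 (1.14 log units; beyond the scatter), concerns the group on the nitrogen itself and does not touch the place changed here. Compound 1 thus stands at the limit of < 0.0167 h in this assay, at which 2 of the 3 values shown sit, with nothing shown beneath it.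

Compound 4 `C=CCN(CCC(=O)OCC)C(=O)/C(C)=C/c1ccc(C(=O)Oc2ccc(C(=N)N)cc2)cc1` differs from compound 1 by ethoxycarbonyl in place of (ethoxycarbonyl)methyl on a saturated chain carbon, two bonds along the chain from an amide-type nitrogen. Among the measured compounds shown here, no measured pair reflects this change, and compound 2, which also carries a short ester chain, sits at the same limit as compound 1. The step in this assay is therefore expected to be none beyond the scatter, a step that the limit leaves unreadable from compound 1 to compound 4. Compound 4 is estimated at 0.01 h, within 0.003 h to 0.03 h, and will most likely be reported as a limit once more.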

Compound 4, half-life: < 0.0167 h
Compound 4: a limit, no number (the forecaster's own chance of this, stated with the estimate: 70%); the middle value does not contradict the limit.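

In this assay compound 4 gives < 0.0167 h, a limit of the assay and not a number. Compound 1 stands at a limit as well, and no step can be read between compound 1 and compound 4. The compounds shown leave open whether the length of the ester chain on the nitrogen changes the half-life at all.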